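Swapping Cyano for Chloro on the Shared Core

The source may hold more compounds than are shown below. What is called first, only, known or untested is meant among the compounds shown, and "the series" means these compounds.

compound 1 `CN1CCC(OC(=O)c2ccc(C#N)cc2)CC1` — 1.65
compound 2 `COc1cc(OC)cc(C(=O)OC2CCN(C)CC2)c1` — 1.53
compound 3 `COc1cc(OC)c(C(=O)OC2CCN(C)CC2)c(OC)c1` — 1.47

These three compounds have been measured in a functional assay on the whole organism with Mus musculus as the target; a lower number here means a less potent compound, a higher number a more potent compound, by a factor of ten per unit of this negative logarithm. Compound 1 gives the highest of the three numbers, but its gaps to compound 2 and to compound 3 both lie within the usual scatter of repeated measurements, so no order among the three can be read from them. Compound 4 `CN1CCC(OC(=O)c2ccc(Cl)cc2)CC1` has not yet been measured. It differs from compound 1 in one place: chloro in place of cyano on an aromatic carbon. Within the data shown here, no measured pair shows this same change, so there is nothing to read a step from. The step of a number 0.05 log units higher from compound 1 to compound 4 (within the scatter) is expected to stay within the scatter, in no clear direction. For compound 4 the expected value in this assay is 1.7, with a range from 1.2 to 2.2.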

Compound 4, logarithm of the reciprocal of the active concentration, log(1/C): 1.11
For compound 4 the middle estimate is 0.59 log units above the measured one, and the stated range ends above it.
By their numbers in this assay, from the lowest: compound 4; then compounds 3, 2 and 1 (each within the scatter of the next).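

Chloro in place of cyano on this aromatic carbon gives a number 0.54 log units lower from compound 1 to compound 4 (beyond the scatter) in this assay and so is the first difference here to stand clear of the scatter. Among these compounds, this single pair shows that the group para to a large group can matter, which the earlier compounds, with no readable order among them, could not show. Nothing available here gives a measured reason for this difference.

On these data alone, whether an amine or a carboxylic acid at this place would read closer to compound 1 or to compound 4 remains open. So does whether this same swap would give a similar step on another core.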